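The compounds below may be only part of what the source reports. "The series", "measured", "known", "first", "only" and "open" are said of these compounds alone.

Measured so far in a functional assay on UACC-62 cells (Homo sapiens) (a higher number here means a weaker inhibitor of growth, a lower number a stronger inhibitor of growth), for this series:
- compound 1 `O=S(=O)(/C=C/c1ccc(F)cc1)Cc1ccc(Nc2ncnc3ccccc23)cc1` gives 5000 nM
- compound 2 `N#Cc1ccc(/C=C/S(=O)(=O)Cc2ccc(Nc3ncnc4ccccc34)cc2)cc1` gives > 100000 nM as a limit, not a number
- compound 3 `CC(C)(C)c1cc(/C=C/S(=O)(=O)Cc2ccc(Nc3ncnc4ccccc34)cc2)cc(C(C)(C)C)c1O` gives 6000 nM

Compound 2 has no number, only a limit: it sits at the limit of > 100000 nM in this assay, at which 1 of the 3 values shown sits (its standing in the series cannot be put more exactly). Compound 4 `O=S(=O)(/C=C/c1ccc(Cl)cc1)Cc1ccc(Nc2ncnc3ccccc23)cc1` has chloro in place of cyano on an aromatic carbon, para to a large group (chloro in place of cyano on an aromatic carbon). Among the compounds with values here, the one measured step at this place (an at least 20-fold higher number from compound 1 to compound 2 (1.30 log units; beyond the scatter)) put cyano in place of fluoro and was large, beyond the scatter. The reverse kind of change is therefore expected to give a large step to a lower number in this assay (an at least 20-fold lower number from compound 2 to compound 4 (1.30 log units; beyond the scatter)), bringing compound 4 close to compound 1 (5000 nM). The expected value for compound 4 is 5000 nM (range 1500 nM to 20000 nM).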

Compound 4, concentration for 50% growth inhibition: 13000 nM
Compound 4: the middle estimate sits 2.6-fold (0.41 log units) below what was measured, and the stated range covers the measured number.
By their numbers in this assay, from the lowest: compounds 1 and 3 (each within the scatter of the next); then compound 4. At a limit, above all of these: compound 2.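

In this assay the change from 4-cyanophenyl to 4-chlorophenyl gives an at least 7.6-fold lower number from compound 2 to compound 4 (0.88 log units; beyond the scatter), so the loss seen with cyano at this place is not shared by chloro. The two halogens do not read alike here either: a 2.6-fold higher number from compound 1 to compound 4 (0.41 log units; beyond the scatter) separates chloro from fluoro, a modest step. From the compounds shown here alone, compound 2 carries a limit and not a number, so the full size of any step from it stays unknown: the limit of > 100000 nM in this assay, at which 1 of the 4 values shown sits.

Going by these compounds, whether the loss belongs to cyano alone stays open. How a methoxy group, an amine or a carboxylic acid at this place would read in this assay is also unknown.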